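The compounds below may be only part of what the source reports. "The series", "measured", "known", "first", "only" and "open" are said of these compounds alone.

Working notes on the series in a functional assay on HeLa cells (Homo sapiens) for inhibition, read by sulforhodamine B assay; on this read-out higher numbers stand for weaker inhibition and lower numbers for stronger inhibition. Compound 1 `O=C1C(Nc2ccc(Br)cc2)=CC(=O)c2c1nc1n2[C@H]2OC[C@@H](O)[C@H]2OC1` gives 5220 nM. Going by the values given here, compound 2 `CCc1ccc(NC2=CC(=O)c3c(nc4n3[C@H]3OC[C@@H](O)[C@H]3OC4)C2=O)cc1` gives 6510 nM; the two numbers lie within the scatter of each other, and the one step recorded, a 1.2-fold higher number from compound 1 to compound 2 (0.10 log units; within the scatter), shows that swapping bromo for ethyl on the aromatic carbon left the read-out essentially unchanged. Compound 3 `CCOc1ccc(NC2=CC(=O)c3c(nc4n3[C@H]3OC[C@@H](O)[C@H]3OC4)C2=O)cc1` is not yet measured; it differs from compound 2 as follows: ethoxy in place of ethyl on an aromatic carbon. Among the compounds with values here, no measured step involves ethoxy, so the only guide is the step from compound 1 to compound 2, which bears on the same site and was within the scatter. On that basis the step from compound 2 to compound 3 is expected to be small, a 1.0-fold lower number from compound 2 to compound 3 (0.00 log units; within the scatter), with no direction that the data can support. Compound 3 is therefore estimated at 6500 nM, with a range from 3000 nM to 14000 nM.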

Compound 3, half-maximal inhibitory concentration: 14400 nM
Compound 3: middle estimate off by 2.2-fold (0.35 log units), on the low side, outside the stated range (above it).
By their numbers in this assay, from the lowest: compounds 1 and 2 (each within the scatter of the next); then compound 3.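

In this assay this place on the aromatic ring, para to a large group, proves not to be indifferent to its substituent: ethoxy gives a 2.2-fold higher number from compound 2 to compound 3 (0.34 log units; beyond the scatter) and a 2.8-fold higher number from compound 1 to compound 3 (0.44 log units; beyond the scatter), both modest and beyond the scatter, whereas bromo and ethyl could not be told apart. The step from ethyl to ethoxy keeps the same count of carbon atoms and adds one oxygen with one hydrogen-bond acceptor, so this site's first readable response goes toward weaker inhibition. Nothing available explains the shift.

From the compounds shown here alone, whether the step follows the oxygen or the overall length of the group stays open; methoxy, propoxy or hydroxyl at this place would help separate the two. Also open, going by these compounds, is whether an amine or a carboxylic acid here would give stronger inhibition than compound 1 and compound 2.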